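Pyridazinone series: tert-butyl to ethyl on the imine nitrogen

The compounds below may be only part of what the source reports. "The series", "measured", "known", "first", "only" and "open" are said of these compounds alone.

Measured compounds:
- compound 1, `CC(C)(C)/N=C(\S)NCCCCn1nc(-c2ccccc2)ccc1=O`: 33.6%
- compound 2, `C/N=C(/NC#N)NCCCCCn1nc(C)ccc1=O`: 14.9%
- compound 3, `C/N=C(/NC#N)NCCCn1nc(-c2ccccc2)c(C)cc1=O`: 17.2%

In a functional assay on the whole organism with Rattus norvegicus as the target, at a dose of 100 mg/kg (on this read-out lower numbers stand for less inhibition and higher numbers for more inhibition at the one dose given (going by the name of the read-out)), compound 1 gives 33.6%, the highest of the three numbers. Compound 3 sits closest to it, and its reading in this assay is lower by a gap beyond the scatter; compound 2 is furthest, also beyond the scatter. No pair among these three differs in only one place, so no single change can be tied to a step.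

Compound 4, `CC/N=C(\S)NCCCCn1nc(-c2ccccc2)ccc1=O`, is the next compound to be run in this assay. It differs from compound 1 in one place: ethyl in place of tert-butyl on a double-bonded nitrogen. Among the compounds with values here, the replacement of one alkyl by a smaller one on the same nitrogen is a small change, and the only information on how this assay responds to such a swap comes from compound 1 itself, with its 33.6%. A step of modest size is expected, most likely downward, but a result within the scatter would not surprise; the step from compound 1 to compound 4 is estimated at a number 6.6 percentage points lower from compound 1 to compound 4 (within the scatter). For compound 4 the expected value in this assay is 27%, with a range from 12% to 42%.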

Compound 4, a percentage reported as inhibition, in the whole organism at one dose (the size of the read-out at that dose, not a potency): 67.7%
Compound 4: middle estimate off by 40.7 percentage points, on the low side; the whole stated range lies below it.
By their numbers in this assay, from the lowest: compounds 2 and 3 (each within the scatter of the next); then compound 1; then compound 4.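

In this assay, the alkyl group on the double-bonded nitrogen carries real weight: ethyl in place of tert-butyl is a large step, a number 34.1 percentage points higher from compound 1 to compound 4 (beyond the scatter). Within the data shown here, this is the first single-place step, and it shows that this swap alone, with the rest of compound 1 held fixed, moves the read-out well beyond the scatter. Nothing at hand bears on why the step is so large, so its origin stays unassigned.

Going by these compounds, a single step sets no trend, so it remains open whether the read-out follows the carbon count of the group on this nitrogen; isopropyl or cyclopropyl there would test this. Also open, on these data alone, is whether the same swap gives a comparable step on a longer chain or with a different group on the shared core.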